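The source may hold more compounds than are shown below. What is called first, only, known or untested is meant among the compounds shown, and "the series" means these compounds.

Within the data shown here, compound 3 `O=C(COc1ccc2c(=O)ccoc2c1)Nc1cccc(NC(=O)c2cnc(C(F)(F)F)s2)c1` stands lowest of the three numbers measured so far in an assay on isolated protein for inhibition of Rho-associated protein kinase 2 (Homo sapiens), read by scintillation counting, radiometric assay and 33P incorporation, with a stated time of 40 min, in the presence of a further agent that is not named here (on this read-out lower numbers stand for stronger inhibition and higher numbers for weaker inhibition), at 10 nM. Compound 1 `CC(=O)Nc1cccc(NC(=O)COc2ccc3c(=O)ccoc3c2)c1` gives 136 nM in this assay, and compound 2 `CCCC(=O)Nc1cccc(NC(=O)COc2ccc3c(=O)ccoc3c2)c1` gives 176 nM. The step of a 1.3-fold higher number from compound 1 to compound 2 (0.11 log units; within the scatter) is small, whereas the two steps that replace a short chain on the carbonyl carbon with a ring are the large ones: a 14-fold lower number from compound 1 to compound 3 (1.13 log units; beyond the scatter) and an 18-fold lower number from compound 2 to compound 3 (1.25 log units; beyond the scatter).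

Compound 4 `Nc1cccc(C(=O)Nc2cccc(NC(=O)COc3ccc4c(=O)ccoc4c3)c2)c1` has not yet been measured. It differs from compound 3 in one place: 3-aminophenyl in place of 2-(trifluoromethyl)-1,3-thiazol-5-yl on a carbonyl carbon. Among the measured compounds shown here, no measured step exchanges one ring for another at this carbonyl carbon; the steps that bear on the place are a 14-fold lower number from compound 1 to compound 3 (1.13 log units; beyond the scatter) and an 18-fold lower number from compound 2 to compound 3 (1.25 log units; beyond the scatter), and both show that what sits on this carbonyl carbon can move the number far. Compound 4 keeps a ring there, so its number is expected to remain between those of compound 3 and compound 1, with a moderate rise beyond the scatter; the expected step is a 4.0-fold higher number from compound 3 to compound 4 (0.60 log units; beyond the scatter). Compound 4 is therefore estimated to give 40 nM in this assay, with a range of 10 nM to 160 nM.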

Compound 4, half-maximal inhibitory concentration: 58 nM
The estimate for compound 4 lay 1.5-fold (0.16 log units) below the measured number; the range from low to high includes it.
By their numbers in this assay, from the lowest: compound 3; then compound 4; then compounds 1 and 2 (each within the scatter of the next).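

Here one ring replaces another on this carbonyl carbon, an exchange the earlier compounds did not offer, and in this assay the identity of the ring proves to matter, with a 5.8-fold higher number from compound 3 to compound 4 (0.76 log units; beyond the scatter) as the step. The 3-aminophenyl group still gives lower numbers than either short chain, with a 2.3-fold lower number from compound 1 to compound 4 (0.37 log units; beyond the scatter) and a 3.0-fold lower number from compound 2 to compound 4 (0.48 log units; beyond the scatter) as the steps, yet these are smaller than the steps reached with the 2-(trifluoromethyl)-1,3-thiazol-5-yl group, so across these four compounds both rings improve on both chains, but by amounts that depend on the ring. Nothing available gives a measured reason for the difference between the two rings.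

The compounds shown do not separate the ring from its substituent, since the 3-aminophenyl group and the 2-(trifluoromethyl)-1,3-thiazol-5-yl group differ in both at once, so a plain phenyl ring carrying no amine, or a 1,3-thiazol-5-yl ring without the trifluoromethyl, would be needed to tell the two apart. They also leave open how a carboxylic acid on the phenyl ring in place of the amine, or a pyridine ring on this carbonyl carbon, would read.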